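From benzoyl to phenylsulfonyl on the shared core

This account rests on a few compounds, and the source may have more. Where it says the series, first, only, none or still open, it means among the compounds named here.

In a functional assay on KB cells (Homo sapiens) for cytotoxicity (on this read-out lower numbers stand for stronger inhibition and higher numbers for weaker inhibition), three amides on a shared core have been measured. Compound 1 (`COc1ccc(S(=O)(=O)N2CCc3cccc(NC(=O)c4ccc(F)cc4)c32)cc1`) gives 93 nM and compound 2 (`COc1ccc(S(=O)(=O)N2CCc3cccc(NC(=O)c4ccncc4)c32)cc1`) gives 9.6 nM while compound 3 (`COc1ccc(S(=O)(=O)N2CCc3cccc(NC(=O)c4ccccc4)c32)cc1`) gives 297 nM as the highest of the three numbers. Compound 4 (`COc1ccc(S(=O)(=O)N2CCc3cccc(NS(=O)(=O)c4ccccc4)c32)cc1`) is still unmeasured. It differs from compound 3 by phenylsulfonyl in place of benzoyl on a nitrogen on an aromatic ring with phenylsulfonyl in place of benzoyl on a nitrogen on an aromatic ring.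

Within the data shown here, no measured step makes this kind of change. All three alter only the group on the carbonyl carbon, which leaves the carbonyl itself in place. The series shows a 3.2-fold higher number from compound 1 to compound 3 (0.50 log units; beyond the scatter) and a 9.7-fold lower number from compound 1 to compound 2 (0.99 log units; beyond the scatter) as modest steps and a 31-fold higher number from compound 2 to compound 3 (1.49 log units; beyond the scatter) as a large one. They therefore offer only a rough guide to size, and the direction remains a judgement without a measured precedent. A modest move to a higher number is expected, with its size taken from a 3.2-fold higher number from compound 1 to compound 3 (0.50 log units; beyond the scatter) and a wide range kept open in view of a 31-fold higher number from compound 2 to compound 3 (1.49 log units; beyond the scatter) as the largest step seen. The step expected in this assay is a 2.7-fold higher number from compound 3 to compound 4 (0.43 log units; beyond the scatter) on this reasoning. Compound 4 is estimated at 800 nM with an expected range from 150 nM to 4000 nM in this read-out.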

Compound 4, half-maximal inhibitory concentration: 650 nM
Beside the measured number, compound 4's estimate is 1.2-fold (0.09 log units) above it, and the stated range covers the measured number.
By their numbers in this assay, from the lowest: compound 2; then compound 1; then compound 3; then compound 4.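

In this assay, among these compounds, phenylsulfonyl in place of benzoyl on a nitrogen on an aromatic ring gives a 2.2-fold higher number from compound 3 to compound 4 (0.34 log units; beyond the scatter), the first reading at this position for a change to the carbonyl itself rather than to the group it carries. This modest step is smaller than the change among the groups on the carbonyl carbon, which reaches a 31-fold higher number from compound 2 to compound 3 (1.49 log units; beyond the scatter), and the wider gaps, a 7.0-fold higher number from compound 1 to compound 4 (0.84 log units; beyond the scatter) and a 68-fold higher number from compound 2 to compound 4 (1.83 log units; beyond the scatter), combine the loss of the carbonyl with the loss of 4-fluoro or of the pyridin-4-yl nitrogen, so compound 4 ends with the highest number of the four while the sulfonyl link alone accounts for only part of those gaps. Nothing at hand explains the direction or size of these steps.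

The compounds shown leave open whether the gain seen with pyridin-4-yl and the smaller one seen with 4-fluorophenyl on the carbonyl carbon would carry over to the same groups on the sulfonyl. They also leave open how the number would respond to a methyl or a longer alkyl chain on the sulfonyl in place of phenyl, or to a urea in place of the amide.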